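The compounds below may be only part of what the source reports. "The series", "measured", "known", "first", "only" and "open" are said of these compounds alone.

Measured so far in a functional assay on HUVEC cells (Homo sapiens) for inhibition (on this read-out lower numbers stand for stronger inhibition and higher numbers for weaker inhibition), are these compounds:

- Compound 1 `COc1cc(/C=C/C(=O)c2cccc(NC(=O)c3cc(Cl)cc(Cl)c3)c2)ccc1O` gives 0.75 ug/mL
- Compound 2 `COc1cc(/C=C/C(=O)c2cccc(N)c2)ccc1O` gives 2.87 ug/mL
- Compound 3 `COc1cc(/C=C/C(=O)c2cccc(NC(=O)c3ccc(Cl)cc3Cl)c2)ccc1O` gives 0.4 ug/mL

The change a 1.9-fold lower number from compound 1 to compound 3 (0.27 log units; within the scatter) stays within the scatter, so compound 3 shares the low end of these three numbers with compound 1. The next compound to be tested is compound 4 `COC(=O)C(=O)Nc1cccc(C(=O)/C=C/c2ccc(O)c(OC)c2)c1`, which has methoxycarbonyl in place of 2,4-dichlorophenyl on a carbonyl carbon, a difference counted as methoxycarbonyl in place of 2,4-dichlorophenyl on a carbonyl carbon in full.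

Within the data shown here, two measured steps bear on this change. One is a 3.8-fold higher number from compound 1 to compound 2 (0.58 log units; beyond the scatter) on swapping the (3,5-dichlorophenyl)carbonyl for hydrogen. The other is a 7.2-fold lower number from compound 2 to compound 3 (0.86 log units; beyond the scatter) on swapping hydrogen for (2,4-dichlorophenyl)carbonyl. Both are modest but beyond the scatter. Among the measured compounds shown here, compound 4 keeps a carbonyl on the nitrogen yet loses the dichlorophenyl, and no measured compound shows a group without a ring in that place, so the size of the step is uncertain. A move partway back towards compound 2 at 2.87 ug/mL seems the most reasonable expectation. The expected change is a 4.0-fold higher number from compound 3 to compound 4 (0.60 log units; beyond the scatter) in this estimate. For compound 4 the estimated value is 1.6 ug/mL, with an expected range from 0.6 ug/mL to 4.5 ug/mL in this assay once measured.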

Compound 4, half-maximal inhibitory concentration: 1.5 ug/mL
The estimate for compound 4 lay 1.1-fold (0.03 log units) above the measured number; the measured number falls inside the stated range.
By their numbers in this assay, from the lowest: compounds 3, 1, 4 and 2 (each within the scatter of the next, the first and the last beyond it).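

In this assay, methoxycarbonyl, a group with no ring, in place of 2,4-dichlorophenyl on the carbonyl carbon gives a 3.8-fold higher number from compound 3 to compound 4 (0.57 log units; beyond the scatter) and this step lies beyond the scatter, so a carbonyl on the nitrogen does not by itself match the result of the dichlorophenyl amide. Placing (methoxycarbonyl)carbonyl on the nitrogen instead of hydrogen gives a 1.9-fold lower number from compound 2 to compound 4 (0.28 log units; within the scatter) and methoxycarbonyl in place of 3,5-dichlorophenyl gives a 2.0-fold higher number from compound 1 to compound 4 (0.30 log units; within the scatter) and, with both steps within the scatter, the new compound cannot be told apart from either the free amine or the 3,5-dichlorophenyl amide. Nothing measured here explains why the group on this carbonyl carbon makes a difference.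

The compounds shown leave open whether the ring or its chlorine atoms account for the step, which a plain phenyl on this carbonyl carbon would help to separate. They also leave open how a small group without a ring behaves here beyond methoxycarbonyl, for instance a methyl group or a carboxylic acid on the same carbon.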